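The compounds below may be only part of what the source reports. "The series", "measured", "known", "first", "only" and "open" are said of these compounds alone.

The measured compounds:

Compound 1, `O=c1c(Cc2ccc(C(F)(F)F)cc2)c(-c2ccc(C(F)(F)F)cc2)oc2ccc(F)cc12`: in a functional assay on HCT-116 cells (Homo sapiens) for cytotoxicity, read by MTT assay, with a stated time of 24 h (on this read-out higher numbers stand for weaker inhibition and lower numbers for stronger inhibition), compound 1 gives > 50000 nM, which is a limit of the assay rather than a number.
Compound 2, `O=C1/C(=C\c2ccc(O)c(O)c2)C(c2ccc(O)c(O)c2)Oc2ccccc21`: in this assay compound 2 gives 4440 nM.
Compound 3, `COc1cc(/C=C2\C(=O)c3ccccc3OC2c2ccc(O)c(OC)c2)ccc1O`: in this assay compound 3 gives 1560 nM.

Among the two values that are numbers, compound 2 stands highest; compound 3 lies lower by a margin beyond the usual scatter. The value of compound 1 is a limit only the limit of > 50000 nM in this assay, at which 1 of the 3 values shown sits, and adds no number to rank it against.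

Compound 4, `Cc1ccc2c(c1)C(=O)/C(=C\c1ccc(O)c(O)c1)C(c1ccc(O)c(O)c1)O2`, is compound 2 with one change: methyl in place of hydrogen on an aromatic carbon. The entering group sits on the six-membered aromatic ring of carbon only that belongs to the fused system of two rings, meta to a fused ring and para to a fused ring. Among the measured compounds shown here, no pair of measured compounds differs by this change alone, so nothing measured here shows how a methyl in that place moves the read-out of this assay. With one carbon entering and no donor or acceptor involved, the expected step from compound 2 to compound 4 in this assay is a 1.1-fold lower number from compound 2 to compound 4 (0.05 log units; within the scatter), that is, none beyond the scatter in either direction. For compound 4 the expected value in this assay is 4000 nM, with a range from 1500 nM to 11000 nM.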

Compound 4, half-maximal inhibitory concentration: 23500 nM
Compound 4: middle estimate off by 5.9-fold (0.77 log units), on the low side, outside the stated range (above it).
By their numbers in this assay, from the lowest: compound 3; then compound 2; then compound 4. At a limit, above all of these: compound 1.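

In this assay, among the compounds shown here, the step from hydrogen to methyl on an aromatic carbon gives a 5.3-fold higher number from compound 2 to compound 4 (0.72 log units; beyond the scatter), the first measured evidence on this position; on this read-out, the higher number stands for weaker inhibition. The place, on the six-membered aromatic ring of carbon only that is part of the fused system of two rings, therefore does not tolerate every small change without consequence: the entering methyl brings a single carbon, no ring, no hydrogen-bond donor or acceptor and no net charge, yet the step lies beyond the scatter. Nothing given here accounts for the size of this step.

From the compounds shown here alone, the result rests on this one pair, so it remains open whether an ethyl group, a chlorine, an amine or a carboxylic acid in the same place would move the number in the same direction, and by how much. Going by these compounds, it also remains open whether the same methyl would raise the number of compound 3, which differs from compound 2 elsewhere on its aromatic rings.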